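Plasma half-life in a hydroxyphenyl triazene series: working notes

A few compounds are considered here, and "the series" means these few. Any claim that something is new, unique, unknown or untested is made for them only; others in the source may bear on it.

Measured compounds in an ADME assay on a cell-free system (plasma, Homo sapiens) for metabolic stability, read by HPLC; on this read-out higher numbers stand for a longer-lived compound and lower numbers for a shorter-lived compound:
- compound 1, `COC(=O)c1ccc(/N=N/N(C)C(=O)CCc2cccc(O)c2)cc1`, gives 7.8 h
- compound 2, `CN(/N=N/c1ccc(C#N)cc1)C(=O)CCCCc1ccc(O)cc1`, gives 11.8 h
- compound 3, `COC(=O)c1ccc(/N=N/N(C)C(=O)CCCCc2ccc(O)cc2)cc1`, gives 17.5 h

Compound 4, `CN(/N=N/c1ccc(C#N)cc1)C(=O)CCc1cccc(O)c1`, has not yet been run in this assay. Two structural changes connect the four compounds. The cores of compound 3 and compound 1 differ by 3-hydroxyphenyl in place of 2-(4-hydroxyphenyl)ethyl on a saturated chain carbon, two bonds along the chain from a carbonyl carbon; in the reverse direction this is the measured step of a 2.2-fold higher number from compound 1 to compound 3 (0.35 log units; beyond the scatter), a modest step beyond the scatter, and compound 1 holds the lowest of the three numbers, with compound 2 within the scatter of it.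

The second change is the same in both pairs: from compound 3 to compound 2 it is cyano in place of methoxycarbonyl on an aromatic carbon, and from compound 1 to compound 4 it is cyano in place of methoxycarbonyl on an aromatic carbon. The two place descriptions agree word for word, so it is the same change, occurring in both pairs among the compounds here. For the measured compounds named here, its one measured step is a 1.5-fold lower number from compound 3 to compound 2 (0.17 log units; within the scatter), which lies within the scatter.

Going by the values given here, on that basis the step from compound 1 to compound 4 is expected to be small as well, about a 1.4-fold lower number from compound 1 to compound 4 (0.15 log units; within the scatter) in this assay, resting on the single measured step of a 1.5-fold lower number from compound 3 to compound 2 (0.17 log units; within the scatter) and on the scatter of the read-out. Among the compounds with values here, compound 4 is therefore estimated at 5.5 h, with a likely range from 3.2 h to 10.5 h, because compound 1 gives 7.8 h and the one precedent for this change moved the number by a 1.5-fold lower number from compound 3 to compound 2 (0.17 log units; within the scatter). Whether the change behaves the same on the shorter core of compound 1 is what the measurement will show.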

Compound 4, half-life: 2.7 h
Estimate against measurement, compound 4: 2.0-fold (0.31 log units) above, and the stated range ends above it.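

In this assay, for the compounds shown here, cyano in place of methoxycarbonyl on an aromatic carbon gives a 2.9-fold lower number from compound 1 to compound 4 (0.46 log units; beyond the scatter), a step on this shorter core that lies beyond the scatter, whereas the one earlier step for the same change lies within it. Set side by side, the two steps do not separate from each other by more than two such steps can scatter: the same change on two cores in this assay, a 1.5-fold lower number (0.17 log units; within the scatter) from compound 3 to compound 2 and a 2.9-fold lower number (0.46 log units; beyond the scatter) from compound 1 to compound 4, 1.9-fold (0.29 log units) apart, within the scatter of two such steps. Going by these compounds alone, the half-lives therefore give no sign that the change acts differently on the two cores, but only one of the two steps clears the scatter, and two pairs can neither establish a constant size for the change nor rule out a modest dependence on the core.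

The compounds shown leave open whether another group in the same place, such as a carboxylic acid, a primary amide or trifluoromethyl, would fall in line with cyano and methoxycarbonyl. They also leave open how the change behaves on a core with a longer chain, or on one carrying a methoxy group in place of the hydroxyl, since the two cores here span only 3-hydroxyphenyl and 2-(4-hydroxyphenyl)ethyl.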